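A few compounds are considered here, and "the series" means these few. Any claim that something is new, unique, unknown or untested is made for them only; others in the source may bear on it.

In a functional assay on A549 cells (Homo sapiens) for cytotoxicity, read by MTT assay, with a stated time of 72 h (on this read-out higher numbers stand for weaker inhibition and lower numbers for stronger inhibition), compound 3 `O=C1c2c[n+]([O-])c3ccccc3c2C(=O)c2c1c1ccccc1n2CCN1CCCCC1` gives 1080 nM. Compound 1 `O=C1c2c[n+]([O-])c3ccccc3c2C(=O)c2c1c1ccccc1n2Cc1cn(C[C@H](O)CO)nn1` gives 1030 nM, and the step of a 1.0-fold higher number from compound 1 to compound 3 (0.02 log units; within the scatter) leaves the two level. Compound 2 `CN1CCN(CCCn2c3c(c4ccccc42)C(=O)c2c[n+]([O-])c4ccccc4c2C3=O)CC1` gives 140 nM, clearly apart from both.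

Compound 4 `CN1CCN(CCCCCCn2c3c(c4ccccc42)C(=O)c2c[n+]([O-])c4ccccc4c2C3=O)CC1` has not yet been measured. The change from compound 3 is 4-(4-methylpiperazin-1-yl)butyl in place of piperidin-1-yl on a saturated chain carbon, two bonds along the chain from an aromatic nitrogen. It lies on a saturated chain carbon, two bonds along the chain from an aromatic nitrogen, so 4-(4-methylpiperazin-1-yl)butyl takes the place of piperidin-1-yl.

Compound 2 also carries a 4-methylpiperazin-1-yl group, which makes the step of a 7.7-fold higher number from compound 2 to compound 3 (0.89 log units; beyond the scatter) the closest guide, read in reverse. The step of a 7.4-fold lower number from compound 1 to compound 2 (0.87 log units; beyond the scatter) is of similar size and also ends on a lower number at compound 2. Both are modest. Neither isolates the effect of chain length, and the chain in compound 4 is longer than any measured here, so the size of the step remains uncertain.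

A step of comparable or slightly smaller size towards a lower number is therefore expected in this assay. The expected change is a 5.4-fold lower number from compound 3 to compound 4 (0.73 log units; beyond the scatter). For compound 4 the estimated value is 200 nM, with an expected range of 60 nM to 650 nM.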

Compound 4, half-maximal inhibitory concentration: 330 nM
Compound 4: middle estimate off by 1.7-fold (0.22 log units), on the low side; the measured number falls inside the stated range.
By their numbers in this assay, from the lowest: compound 2; then compound 4; then compounds 1 and 3 (each within the scatter of the next).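

In this assay, the 4-methylpiperazin-1-yl group again goes with a lower number when it stands at the end of a longer chain: a 3.3-fold lower number from compound 3 to compound 4 (0.51 log units; beyond the scatter), and a 3.1-fold lower number from compound 1 to compound 4 (0.49 log units; beyond the scatter), so among these compounds both members carrying that group, compound 2 and compound 4, lie lower than compound 1 and compound 3, with no compound here going against this. Going by these compounds alone, the new compound also gives the first comparison in which the 4-methylpiperazin-1-yl group is held fixed and only the chain changes: a 2.4-fold higher number from compound 2 to compound 4 (0.37 log units; beyond the scatter), so the longer chain gives back part of the drop, though compound 4 still stays clearly lower than compound 3. No measurement is available here that explains these differences.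

The step from compound 3 to compound 4 changes the chain and the end ring together, so a piperidin-1-yl group on the longer chain of compound 4 would be needed to separate the two changes. Within the data shown here, whether the number rises steadily with chain length also stays open, as only two chain lengths carry the 4-methylpiperazin-1-yl group, and a morpholine ring or a primary amine at the chain end would test how far the result depends on that group.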